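Adding a hydroxy to compound 1: working notes

A few compounds are considered here, and "the series" means these few. Any claim that something is new, unique, unknown or untested is made for them only; others in the source may bear on it.

Values in a functional assay on MCF7 cells (Homo sapiens) for inhibition, with a stated time of 72 h; on this read-out lower numbers stand for stronger inhibition and higher numbers for weaker inhibition:
- compound 1 `NC1CCC(Nc2nc(NCc3ccc(-c4ccccc4)cc3)c3ncn(C4CCCC4)c3n2)CC1` gives 583 nM
- compound 2 `NC1CCC(Nc2nc(NCc3ccc(-c4cccc(F)c4)nc3)c3ncn(C4CCCC4)c3n2)CC1` gives 33 nM
- compound 3 `NC1CCC(Nc2nc(NCc3ccc(-c4ccco4)nc3)c3ncn(C4CCCC4)c3n2)CC1` gives 33 nM
- compound 4 `NC1CCC(Nc2nc(NCc3ccc(-c4ccccc4O)cc3)c3ncn(C4CCCC4)c3n2)CC1` is not yet measured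

Compound 1 has the highest number of the three, and the values of the other two compounds are identical. Compound 4 keeps the core of compound 1 and differs in one place: hydroxy in place of hydrogen on an aromatic carbon. This is hydroxy in place of hydrogen on an aromatic carbon, ortho to a large group, or phenyl to 2-hydroxyphenyl.

For the measured compounds named here, no measured step adds a hydroxy, so the evidence is indirect. One step shows an 18-fold lower number from compound 1 to compound 3 (1.25 log units; beyond the scatter), but it replaces the whole 4-phenylphenyl group and is a poor guide to a single added group. Another shows no change at the digits printed from compound 2 to compound 3 (within the scatter), with furan-2-yl in place of 3-fluorophenyl. A small step towards a lower number is therefore expected in this assay, and no step beyond the scatter would be unsurprising. The estimated change is a 1.5-fold lower number from compound 1 to compound 4 (0.16 log units; within the scatter). For compound 4 the expected value is 400 nM, with an estimated range of 130 nM to 1200 nM.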

Compound 4, half-maximal inhibitory concentration: 2910 nM
Compound 4: the middle estimate sits 7.3-fold (0.86 log units) below what was measured; measured number above the stated range.
By their numbers in this assay, from the lowest: compounds 2 and 3 (each within the scatter of the next); then compound 1; then compound 4.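

Among the compounds shown, only this step isolates one added group: in this assay, phenyl to 2-hydroxyphenyl gives a 5.0-fold higher number from compound 1 to compound 4 (0.70 log units; beyond the scatter). The earlier steps shown here either replace the whole 4-phenylphenyl group or exchange one aromatic substituent for another, so neither tests this position directly. This aromatic carbon, ortho to a large group, is therefore not indifferent to substitution in the core of compound 1, and hydroxy there moves the number in the unfavourable direction. No measurement on hand gives a reason for the rise.

From the compounds shown here alone, it remains open whether a methoxy or an amine on the same aromatic carbon would give a similar step, or whether the step is particular to hydroxy. Going by these compounds, it is also open whether adding a hydroxy to the 3-fluorophenyl ring of compound 2 or the furan-2-yl ring of compound 3 would raise the number.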